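Ring Size on the Aromatic Carbon and Adenosine Binding

The compounds below may be only part of what the source reports. "The series", "measured", "known", "first", "only" and "open" are said of these compounds alone.

Measured so far:
compound 1, `CCCn1c(=O)n(C)c(=O)c2[nH]c(-c3ccccc3)nc21` — 6.3 nM
compound 2, `CCCn1c(=O)n(C)c(=O)c2[nH]c(C3CCCC3)nc21` — 0.85 nM

Two compounds share one core and differ only in the group on an aromatic carbon. In an assay on Cortex for displacement of a labelled ligand from adenosine receptor A1 (Rattus norvegicus) (a higher number here means a weaker inhibitor, a lower number a stronger inhibitor), compound 1 gives 6.3 nM, while compound 2 gives 0.85 nM. Among the measured compounds shown here, the single measured step, a 7.4-fold lower number from compound 1 to compound 2 (0.87 log units; beyond the scatter), follows the change of cyclopentyl in place of phenyl. Compound 2 therefore stands with the lowest of the two numbers, and its nearest neighbour is compound 1, beyond the scatter.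

Compound 3, `CCCn1c(=O)n(C)c(=O)c2[nH]c(C3CCCCC3)nc21`, differs from compound 2 by cyclohexyl in place of cyclopentyl on an aromatic carbon. For the measured compounds named here, no measured step exchanges one non-aromatic ring for another of a different size; the only step on record concerns phenyl against cyclopentyl, so it bears on the present change only loosely, showing that this position tolerates a saturated ring well. A step near the edge of the scatter, toward a higher number, is expected in this assay. Compound 3 is estimated at 2 nM, within a range from 0.7 nM to 6 nM, which means an expected step of a 2.4-fold higher number from compound 2 to compound 3 (0.37 log units; beyond the scatter).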

Compound 3, inhibition constant: 1.81 nM
The estimate for compound 3 lay 1.1-fold (0.04 log units) above the measured number; measured number inside the range.
By their numbers in this assay, from the lowest: compound 2; then compound 3; then compound 1.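

In this assay, among the compounds shown here, the step of a 2.1-fold higher number from compound 2 to compound 3 (0.33 log units; beyond the scatter) is the first exchange of one non-aromatic carbon ring for another on this aromatic carbon, and it shows that the number responds to ring size here, with cyclopentyl giving the lower value of the two. The step of a 3.5-fold lower number from compound 1 to compound 3 (0.54 log units; beyond the scatter) shows that the lower number relative to phenyl is not confined to cyclopentyl, so among these three compounds both saturated rings give lower numbers than the aromatic ring, and none goes against that order. No measurement on hand offers an explanation for these differences or for the order of the three compounds.

The compounds shown leave open whether the number would keep falling with a smaller ring such as cyclobutyl or cyclopropyl, or would rise further with a larger one such as cycloheptyl, since two ring sizes mark out no trend. They also leave open whether a ring is needed at all, as an open chain such as isopentyl could be compared directly with cyclopentyl, and whether a ring nitrogen, as in piperidine, would be accepted in place of a ring carbon.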